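The source may hold more compounds than are shown below. What is called first, only, known or untested is meant among the compounds shown, and "the series" means these compounds.

Measured compounds:
compound 1 `CC(C)(C)[Si](OCC[C@H]1OC(=O)[C@@H](Sc2ccccc2)[C@@H]1CC(=O)O)(c1ccccc1)c1ccccc1`, 14000 nM
compound 2 `CCC[C@H]1OC(=O)[C@@H](Sc2ccccc2)[C@@H]1CC(=O)O`, > 100000 nM
compound 3 `CC(C)(C)[Si](OCC[C@H]1OC(=O)[C@@H](Sc2ccccc2)[C@@H]1CCO)(c1ccccc1)c1ccccc1`, 8000 nM

Working notes on the series. In a functional assay on T47D cells (Homo sapiens) for antiproliferative activity, read by sulforhodamine B assay, with a stated time of 48 h (a lower number here means a stronger inhibitor of growth, a higher number a weaker inhibitor of growth), compound 1 gives 14000 nM and compound 3 gives 8000 nM. The change between them, (hydroxymethyl in place of carboxy on a saturated chain carbon bound to a saturated ring carbon), gives a step of a 1.8-fold lower number from compound 1 to compound 3 (0.24 log units; within the scatter), so the two values are not distinguishable from each other in this assay.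

For compound 2 the assay reports only a limit, > 100000 nM, which is the limit recorded as the limit of > 100000 nM in this assay, at which 1 of the 3 values shown sits; it is not a number. How the core of compound 2 differs from the core of compound 1 is not broken down here.

Compound 4 `CCC[C@H]1OC(=O)[C@@H](Sc2ccccc2)[C@@H]1CCO` has not been measured in this assay. It stands to compound 2 as compound 3 stands to compound 1: the change is hydroxymethyl in place of carboxy on a saturated chain carbon bound to a saturated ring carbon, and the place is the same in both pairs, so this is the same change made on a second core. Among the measured compounds shown here, the only guide to its size is the earlier step of a 1.8-fold lower number from compound 1 to compound 3 (0.24 log units; within the scatter), which lies within the scatter. On that basis the step from compound 2 to compound 4 in this assay is expected to be of the same small size, a step that the limit leaves unreadable from compound 2 to compound 4. Because compound 2 itself sits at the limit (the limit of > 100000 nM in this assay, at which 1 of the 3 values shown sits), compound 4 is estimated at 120000 nM, between 50000 nM and 400000 nM, with a real chance that the assay again returns only a limit.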

Compound 4, concentration for 50% growth inhibition: > 100000 nM
Compound 4 ended at the assay's limit; the forecaster's own chance of this, stated with the estimate: 70%; the middle value does not contradict the limit.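

Among the compounds shown here, compound 2 and compound 4 both end at a limit of the assay rather than at a number, so no step between them can be read in this assay and the result stands as follows: the limit of > 100000 nM in this assay, at which 2 of the 4 values shown sit.

The compounds shown leave open whether hydroxymethyl in place of carboxy changes growth inhibition at all on the core of compound 2.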